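Trimming One Ester Chain on a Weakly Cytotoxic Core

The source may report more compounds than this note shows. Statements on the series, on what has been measured and on what is new or still open speak of the compounds shown alone.

Of the compounds shown here, two built on one shared core have been tested so far. Compound 1, `CC(C)CC(=O)OCC1=CO[C@@H](OC(=O)CC(C)(C)O)[C@H]2C1=C[C@H](OC(=O)CC(C)C)[C@]2(O)COC(=O)CC(C)C`, carries several ester groups around that core. In a functional assay on PC-3M cells (Homo sapiens) for cytotoxicity, read by MTT assay (on this read-out higher numbers stand for weaker inhibition and lower numbers for stronger inhibition), compound 1 gives 8900 nM. Among the compounds with values here, compound 2, `CCC(C)CC(=O)O[C@H]1C=C2C(COC(C)=O)=CO[C@@H](OC(=O)C=C(C)C)[C@@H]2[C@@]1(O)COC(=O)CC(C)C`, shares the core but differs from compound 1 in more than one place, so no single step can be drawn between them. In this assay compound 2 gives 7300 nM. Of the two numbers, that of compound 1 is the higher, yet its gap to compound 2 lies within the scatter of repeated measurements, so the two are best treated as alike.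

Compound 3, `CC(=O)OCC1=CO[C@@H](OC(=O)CC(C)(C)O)[C@H]2C1=C[C@H](OC(=O)CC(C)C)[C@]2(O)COC(=O)CC(C)C`, has not been measured. It differs from compound 1 in one place: hydrogen in place of isopropyl on a saturated chain carbon bound to a carbonyl carbon. Within the data shown here, no measured pair shows this change by itself, so its size can only be expected. Compound 2 also carries an acetoxy group rather than a (isobutylcarbonyl)oxy group and gives 7300 nM, close to compound 1, which hints that shortening this chain changes little here. The expected step is small, a 1.1-fold lower number from compound 1 to compound 3 (0.05 log units; within the scatter), not beyond the scatter. Compound 3 is therefore estimated to give 8000 nM, within a range from 3500 nM to 18000 nM.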

Compound 3, half-maximal inhibitory concentration: 11100 nM
Compound 3: middle estimate off by 1.4-fold (0.14 log units), on the low side, and the stated range covers the measured number.
By their numbers in this assay, from the lowest: compounds 2, 1 and 3 (each within the scatter of the next).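

Replacing isopropyl with hydrogen on a saturated chain carbon bound to a carbonyl carbon, which turns the (isobutylcarbonyl)oxy group into acetoxy, gives a 1.2-fold higher number from compound 1 to compound 3 (0.10 log units; within the scatter) in this assay on the shared core. Within the data shown here, this is the first pair of compounds that shows this change alone, and it shows that, at this one position, the chain can be cut from isobutyl down to methyl with no difference that stands clear of the usual scatter of repeated measurements, so the two compounds are best treated as alike. Nothing measured here offers an explanation for this result.

Still open, as far as these compounds go, is whether any other group at this position would move the number beyond the scatter, such as a longer chain, an amine or a carboxylic acid in place of the acetoxy methyl. Among these compounds, also open is whether the other ester groups around the core would tolerate the same trimming from isobutyl to methyl, since this single pair speaks only for the one position where the change was made.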